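This account rests on a few compounds, and the source may have more. Where it says the series, first, only, none or still open, it means among the compounds named here.

Measured so far in a functional assay on the whole organism for antagonist activity, with Mus musculus as the target; a lower number here means that less compound is needed, a higher number that more compound is needed for the effect:
compound 1 `COc1cc(N)c(Cl)cc1NC(=O)C1CCN(C2CCCC2)CC1` gives > 10 mg/kg, a limit of the assay.
compound 2 `CCCN1CCC(C(=O)Nc2cc(Cl)c(N)cc2OC)CC1` gives > 10 mg/kg, a limit of the assay.
compound 3 `CCOc1ccc(CN2CCC(C(=O)Nc3cc(Cl)c(N)cc3OC)CC2)cc1` gives 6.3 mg/kg.

For the measured compounds named here, compound 3 thus stands alone with a read number; the other two values sit at the limit of > 10 mg/kg in this assay, at which 2 of the 3 values shown sit, and say only that more compound would be needed than was dosed. Going by the values given here, of the two measured steps, the one from compound 1 to compound 2 a step that the two limits leave unreadable from compound 1 to compound 2 cannot be read, since both ends are limits. The step from compound 2 to compound 3 an at least 1.5-fold lower number from compound 2 to compound 3 (0.20 log units; that floor lies within the scatter) is the only readable one, and its floor lies within the scatter.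

Compound 4 `COc1cc(N)c(Cl)cc1NC(=O)C1CCN(Cc2ccc(C)c(C)c2)CC1` is not yet measured. The change is 3,4-dimethylphenyl in place of 4-ethoxyphenyl on a saturated chain carbon bound to an amine nitrogen in a ring. Among the compounds with values here, no measured step bears directly on an exchange of one aryl group for another; the only readable step, from compound 2 to compound 3, concerns the arrival of an aryl group and gives no handle on what replacing the ethoxy with two methyls does. With nothing to push the expectation either way, the step from compound 3 to compound 4 is expected to stay within the scatter, a 1.1-fold higher number from compound 3 to compound 4 (0.05 log units; within the scatter). For compound 4 the estimate in this assay is 7 mg/kg, with a range from 3 mg/kg to 20 mg/kg, and a real chance that only a limit is returned.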

Compound 4, dose for half-maximal effect: > 8 mg/kg
Compound 4: only a limit was reported; the forecaster's own chance of this, stated with the estimate: 35%; middle value at least 1.1-fold (0.05 log units) from the limit.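

In this assay compound 4 gives > 8 mg/kg, which is a limit of the assay and not a number. Going by these compounds, exchanging 4-ethoxyphenyl for 3,4-dimethylphenyl on the saturated chain carbon bound to an amine nitrogen in a ring gives an at least 1.2-fold higher number from compound 3 to compound 4 (0.10 log units; that floor lies within the scatter), so this first exchange of one aryl group for another at this position shows no change beyond the scatter, although no read number is returned for the new group and the true size of the step stays unknown. The steps to compound 4 from compound 1 and from compound 2 cannot be read, since both ends of each are limits.

For the compounds shown here, with compound 3 the only one carrying a read number, the series gives no measured comparison between two aryl groups at this position, and the part played by the oxygen of the 4-ethoxyphenyl group stays unresolved. A 4-ethylphenyl or 4-methoxyphenyl group on the same carbon would test that oxygen and the length of the chain more directly than the 3,4-dimethylphenyl group can.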